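This account rests on a few compounds, and the source may have more. Where it says the series, first, only, none or still open, it means among the compounds named here.

Three compounds share one core and differ only in the group that sits on a nitrogen on an aromatic ring. Compound 1 `C=CC(=O)Nc1cccc(NC(=O)CSc2nc(Nc3cccc(C)c3)c3ccccc3n2)c1` carries a 3-methylphenyl there, compound 2 `C=CC(=O)Nc1cccc(NC(=O)CSc2nc(Nc3ccc(F)cc3)c3ccccc3n2)c1` a 4-fluorophenyl and compound 3 `C=CC(=O)Nc1cccc(NC(=O)CSc2nc(Nc3ccc(Cl)cc3)c3ccccc3n2)c1` a 4-chlorophenyl. In a functional assay on NCI-H1975 cells (Homo sapiens) for inhibition, read by MTT assay, with a stated time of 72 h (on this read-out lower numbers stand for stronger inhibition and higher numbers for weaker inhibition), compound 1 gives 12100 nM, compound 2 gives 4430 nM and compound 3 gives 7580 nM. Compound 3 thus stands second highest of the three numbers, yet the gap from compound 1 to compound 3 is a 1.6-fold lower number from compound 1 to compound 3 (0.20 log units; within the scatter) and the gap from compound 2 to compound 3 is a 1.7-fold higher number from compound 2 to compound 3 (0.23 log units; within the scatter), so neither separates it from its neighbours in any firm way.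

Compound 4 `C=CC(=O)Nc1cccc(NC(=O)CSc2nc(Nc3ccc(F)c(Cl)c3)c3ccccc3n2)c1` is a new member of the same series. Its difference from compound 3 is 3-chloro-4-fluorophenyl in place of 4-chlorophenyl on a nitrogen on an aromatic ring. Compound 4 therefore carries both the fluoro seen in compound 2 and the chloro seen in compound 3. Among the compounds with values here, the step that bears on it most directly, a 1.7-fold higher number from compound 2 to compound 3 (0.23 log units; within the scatter), swapped one of these for the other and stayed within the scatter; only the step of a 2.7-fold lower number from compound 1 to compound 2 (0.44 log units; beyond the scatter) went beyond it. A small shift at most is expected, with no firm direction, and the estimated step is a 1.4-fold lower number from compound 3 to compound 4 (0.14 log units; within the scatter). For compound 4 the expected value in this assay is 5500 nM, with a range from 2500 nM to 12000 nM.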

Compound 4, half-maximal inhibitory concentration: > 50000 nM
Compound 4: only a limit was reported; the forecaster's own chance of this, stated with the estimate: 3%; middle value at least 9.0-fold (0.95 log units) away from the limit.
By their numbers in this assay, from the lowest: compounds 2, 3 and 1 (each within the scatter of the next, the first and the last beyond it). At a limit, above all of these: compound 4.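

In this assay, compound 4 gives only a limit of the assay, not a number: the limit of > 50000 nM in this assay, at which 1 of the 4 values shown sits.

Earlier swaps of the group on this nitrogen moved the number only a little, whereas adding one chloro to the ring of compound 2 gives an at least 11-fold higher number from compound 2 to compound 4 (1.05 log units; beyond the scatter), so a single added atom at this place can matter far more than compounds 1 to 3 suggested. The comparisons with the other two compounds point the same way, with an at least 6.5-fold higher number from compound 3 to compound 4 (0.81 log units; beyond the scatter) and an at least 4.1-fold higher number from compound 1 to compound 4 (0.61 log units; beyond the scatter), which shows that a ring carrying both fluoro and chloro does not behave as a blend of the 4-fluorophenyl and 4-chlorophenyl rings, each of which gives a number in this assay.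

How far compound 4 lies beyond its limit stays unknown, and the compounds shown give no cause for the loss of inhibition. From the compounds shown here alone, how a plain phenyl, or a ring bearing a methoxy group or an amine, would behave on this nitrogen also remains open.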